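The source may hold more compounds than are shown below. What is called first, only, known or untested is meant among the compounds shown, and "the series" means these compounds.

Measured in an in vitro ADME assay on microsomes from liver (Rattus norvegicus) for metabolic stability; a lower number here means slower removal, a higher number faster removal of the compound:
- compound 1 `C#CCN(CC=C)C(=O)[C@@]1(c2ccsc2)C[C@H]1CN`: 44 mL/min/kg
- compound 2 `C=CCN(CC=C)C(=O)[C@@]1(c2ccsc2)C[C@H]1CN`: 59 mL/min/kg
- compound 3 `C=CCN(CCOC)C(=O)[C@@]1(c2ccsc2)C[C@H]1CN`: 52 mL/min/kg

Compound 3 cannot be separated from the other two, as a 1.2-fold higher number from compound 1 to compound 3 (0.07 log units; within the scatter) and a 1.1-fold lower number from compound 2 to compound 3 (0.05 log units; within the scatter). Compound 4 `C#CCN(CCOC)C(=O)[C@@]1(c2ccsc2)C[C@H]1CN` differs from compound 3 by one exchange: ethynyl in place of vinyl on a saturated chain carbon bound to an amide-type nitrogen. In words, this is ethynyl in place of vinyl on a saturated chain carbon bound to an amide-type nitrogen.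

The same exchange has been measured once, in the opposite direction: a 1.3-fold higher number from compound 1 to compound 2 (0.13 log units; within the scatter). Reversing that small step suggests, at most, a slight drift towards a lower number in this assay, with nothing expected beyond the scatter. The estimated step is a 1.3-fold lower number from compound 3 to compound 4 (0.10 log units; within the scatter). The expected value for compound 4 is 41 mL/min/kg, within an estimated range of 25 mL/min/kg to 65 mL/min/kg.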

Compound 4, clearance: 18 mL/min/kg
Estimate against measurement, compound 4: 2.3-fold (0.36 log units) above; the measured number lies below the stated range.
By their numbers in this assay, from the lowest: compound 4; then compounds 1, 3 and 2 (each within the scatter of the next).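

In this assay, for the compounds shown here, ethynyl in place of vinyl on a saturated chain carbon bound to an amide-type nitrogen now gives a step beyond the scatter, a 2.9-fold lower number from compound 3 to compound 4 (0.46 log units; beyond the scatter), which the earlier compounds did not show. Its size still cannot be separated from that of the reverse change on the other core: the same change on two cores in this assay, a 1.3-fold higher number (0.13 log units; within the scatter) from compound 1 to compound 2 and a 2.9-fold higher number (0.46 log units; beyond the scatter) from compound 4 to compound 3, 2.2-fold (0.33 log units) apart, within the scatter of two such steps. Methoxymethyl in place of vinyl at this place also gives a step beyond the scatter, a 2.4-fold lower number from compound 1 to compound 4 (0.39 log units; beyond the scatter), but the same limit applies: the same change on two cores in this assay, a 1.1-fold lower number (0.05 log units; within the scatter) from compound 2 to compound 3 and a 2.4-fold lower number (0.39 log units; beyond the scatter) from compound 1 to compound 4, 2.2-fold (0.33 log units) apart, within the scatter of two such steps.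

Open, as far as these compounds go, is how a saturated propyl chain or a chain ending in an amine would behave at this place in this assay.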